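From tert-Butyl to Ethyl: One Step in a Urea Series

This account rests on a few compounds, and the source may have more. Where it says the series, first, only, none or still open, it means among the compounds named here.

Compound 1 `CNc1cc(Oc2ccc(NC(=O)Nc3cccc(C(F)(F)F)c3)cc2)ncn1` gives 40 nM in an assay on isolated protein for inhibition of serine/threonine-protein kinase TNNI3K (Homo sapiens); a lower number here means a stronger inhibitor, a higher number a weaker inhibitor.
Compound 2 `CNc1cc(Oc2ccc(NC(=O)Nc3cccc(C(C)(F)F)c3)cc2)ncn1` gives 40 nM in this assay.
Compound 3 `CNc1cc(Oc2ccc(NC(=O)Nc3cccc(C(C)(C)C)c3)cc2)ncn1` gives 40 nM in this assay.

The three measured compounds share one core and differ only in the group on an aromatic carbon of the ring at the end of the urea. The step of no change at the digits printed from compound 1 to compound 2 (within the scatter) and the step of no change at the digits printed from compound 1 to compound 3 (within the scatter) both sit within the scatter, and so does the step of no change at the digits printed from compound 2 to compound 3 (within the scatter). Compound 3 therefore stands level with compound 1 and compound 2; nothing in these numbers separates the three.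

Compound 4 `CCc1cccc(NC(=O)Nc2ccc(Oc3cc(NC)ncn3)cc2)c1` is the next member. The change from compound 3 is ethyl in place of tert-butyl on an aromatic carbon. Going by the values given here, no measured step exchanges tert-butyl for ethyl, so the closest guide is the indifference of this assay to the three groups already tried, as the steps from compound 1 and compound 2 to compound 3 show. On that basis compound 4 is expected to change by a 1.3-fold higher number from compound 3 to compound 4 (0.10 log units; within the scatter), that is, not beyond the scatter, though a smaller group carries more uncertainty than the earlier swaps. Compound 4 is thus estimated at 50 nM, with a range from 20 nM to 130 nM.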

Compound 4, half-maximal inhibitory concentration: 200 nM
The estimate for compound 4 lay 4.0-fold (0.60 log units) below the measured number; the whole stated range lies below it.
By their numbers in this assay, from the lowest: compounds 1, 2 and 3 (each within the scatter of the next); then compound 4.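

In this assay, this position proves not to be indifferent to its group: ethyl in place of tert-butyl gives a 5.0-fold higher number from compound 3 to compound 4 (0.70 log units; beyond the scatter), ethyl in place of 1,1-difluoroethyl gives a 5.0-fold higher number from compound 2 to compound 4 (0.70 log units; beyond the scatter), and ethyl in place of trifluoromethyl gives a 5.0-fold higher number from compound 1 to compound 4 (0.70 log units; beyond the scatter). The three earlier compounds showed only that those groups could replace one another on this aromatic carbon without a change beyond the scatter, whereas ethyl, with 2 heavy atoms against the 4 of tert-butyl, is the one group shown here that separates from them. Nothing available here accounts for this separation.

A single ethyl compound cannot show whether the higher number follows the number of heavy atoms in the group or some other feature of ethyl. Going by these compounds, how methyl, isopropyl or cyclopropyl on the same aromatic carbon would read in this assay remains open, and so does whether ethyl is an isolated case or part of a wider trend at this position.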